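Removing the fluoro from compound 2: notes on compound 3

The compounds below may be only part of what the source reports. "The series", "measured", "known", "first", "only" and "open" are said of these compounds alone.

Measured so far:
compound 1 `O=C(Oc1ccccc1)N1CCC(CCn2ccc3ncccc32)CC1` — in an assay on microsomes from brain for inhibition of Fatty-acid amide hydrolase 1 (Rattus norvegicus), read by HPLC, with a stated time of 60 min (a lower number here means a stronger inhibitor, a higher number a weaker inhibitor), compound 1 gives 1700 nM
compound 2 `O=C(Oc1ccccc1)N1CCC(CCn2ccc3cccc(F)c32)CC1` — in this assay compound 2 gives 52 nM

Of the compounds shown here, two have been measured. Compound 2 stands at the low end of the pair, with the lower of the two numbers; the gap to compound 1 lies well beyond the usual scatter. Compound 1 and compound 2 differ in more than one place, so their values show only the overall difference between them, and no single structural change can be read from that pair.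

Compound 3 `O=C(Oc1ccccc1)N1CCC(CCn2ccc3ccccc32)CC1` has not yet been measured. It differs from compound 2 in one place: hydrogen in place of fluoro on an aromatic carbon. For the measured compounds named here, no measured pair shows a change of this kind, so the size of the step has to be guessed. A single fluorine leaving an aromatic ring is expected to move the number upward by a small to moderate amount, though a result within the scatter would not surprise. Compound 3 is therefore expected to give 110 nM, with a likely range from 35 nM to 350 nM. The expected step is a 2.1-fold higher number from compound 2 to compound 3 (0.33 log units; beyond the scatter).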

Compound 3, half-maximal inhibitory concentration: 110 nM
The estimate for compound 3 equals the measured number at the digits printed; measured number inside the range.
By their numbers in this assay, from the lowest: compound 2; then compound 3; then compound 1.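

In this assay the series now has its first reading of a single change: hydrogen in place of fluoro on an aromatic carbon, ortho to a fused ring and meta to a fused ring, gives a 2.1-fold higher number from compound 2 to compound 3 (0.33 log units; beyond the scatter) as a modest step. Fluoro at this carbon therefore contributes to the lower number of compound 2, but the inhibition does not depend on it, since compound 3, which carries only hydrogen there, still gives 110 nM in this series. Nothing available for these compounds accounts for the size of this step.

From the compounds shown here alone, it remains open whether the lower number is specific to fluoro or would also follow from another small group on this carbon, such as chloro, methyl or methoxy, and whether fluoro on another carbon of the same six-membered aromatic ring would give a step of similar size. For the compounds shown here, a single pair also cannot show whether the same exchange would give a similar step on a different core, or with a carbamate group other than the one shared by these compounds.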